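This account rests on a few compounds, and the source may have more. Where it says the series, first, only, none or still open, it means among the compounds named here.

Within the data shown here, compound 2 `C[C@H](NC(=O)c1cc(C(F)(F)F)nn1C)c1nc(-c2ccnc(C3CC3)c2)no1` gives 16 nM in an assay on T-REx-293 cells for inhibition of potassium channel subfamily T member 1 (Homo sapiens), read by patch clamp (a lower number here means a stronger inhibitor, a higher number a weaker inhibitor), the lowest of the two numbers known so far; compound 1 `Cc1cncc(-c2noc([C@H](C)NC(=O)c3cc(C(F)(F)F)nn3C)n2)c1` gives 1370 nM. The large step of an 86-fold lower number from compound 1 to compound 2 (1.93 log units; beyond the scatter) came from exchanging the whole six-membered aromatic ring with one nitrogen and its group. Compound 3 `COCc1cc(-c2noc([C@H](C)NC(=O)c3cc(C(F)(F)F)nn3C)n2)ccn1` keeps the ring of compound 2 and differs only by methoxymethyl in place of cyclopropyl on an aromatic carbon. Among the measured compounds shown here, no measured step swaps a group at this place alone, so the size of an 86-fold lower number from compound 1 to compound 2 (1.93 log units; beyond the scatter) only shows that this region weighs heavily; a moderate weakening is expected. Compound 3 is estimated at 45 nM, between 10 nM and 200 nM. That expectation corresponds to a 2.8-fold higher number from compound 2 to compound 3 (0.45 log units; beyond the scatter).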

Compound 3, half-maximal inhibitory concentration in the potassium channel subfamily T member 1 assay: 322 nM
Compound 3: the middle estimate sits 7.2-fold (0.85 log units) below what was measured; the whole stated range lies below it.
By their numbers in the potassium channel subfamily T member 1 assay, from the lowest: compound 2; then compound 3; then compound 1.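

In the potassium channel subfamily T member 1 assay, the group on this aromatic carbon matters a great deal by itself: with the rest of the molecule unchanged, methoxymethyl in place of cyclopropyl gives a 20-fold higher number from compound 2 to compound 3 (1.30 log units; beyond the scatter). The 2-(methoxymethyl)pyridin-4-yl ring still does better than 5-methylpyridin-3-yl, with a 4.3-fold lower number from compound 1 to compound 3 (0.63 log units; beyond the scatter). The weaker inhibition comes with a gain in a physicochemical assay for solubility, measured as kinetic solubility; a lower number here means a less soluble compound, a higher number a more soluble compound: the measured solubility of compound 2, 16000 nM, and of compound 3, 200000 nM, a 13-fold higher number (1.10 log units; beyond the scatter) In the physicochemical assay compound 2 gives 16000 nM and compound 3 gives 200000 nM.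

The compounds shown do not separate losing the three-membered ring from gaining the oxygen. From the compounds shown here alone, whether an ethyl group or an amine on this carbon could combine the inhibition of compound 2 with the solubility of compound 3 remains open.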